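A Second Phenyl on the Urea Side Chain

The source may report more compounds than this note shows. Statements on the series, on what has been measured and on what is new or still open speak of the compounds shown alone.

Two ureas built on the shared core have been measured in an assay on microsomes from intestine for inhibition of acyl-CoA:cholesterol acyltransferase (Oryctolagus cuniculus); on this read-out lower numbers stand for stronger inhibition and higher numbers for weaker inhibition. Compound 1 `CC(C)c1cccc(C(C)C)c1NC(=O)NCc1ccccc1` gives 360 nM in this assay, and compound 2 `CC(C)c1cccc(C(C)C)c1NC(=O)NCCCc1ccccc1` gives 191 nM. Among the measured compounds shown here, the one step between them, a 1.9-fold lower number from compound 1 to compound 2 (0.28 log units; within the scatter), lengthens the chain between the urea nitrogen and the ring. Compound 2 thus stands at the lowest of the two numbers shown, at a distance from compound 1 that lies within the scatter, so no order between them can be claimed.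

Compound 3 `CC(C)c1cccc(C(C)C)c1NC(=O)NCCC(c1ccccc1)c1ccccc1` has not been measured. It differs from compound 2 by phenyl in place of hydrogen on a saturated chain carbon bound to an aromatic carbon and a saturated chain carbon. For the measured compounds named here, only one measured step bears on this change, and only loosely: a 1.9-fold lower number from compound 1 to compound 2 (0.28 log units; within the scatter) altered the chain, whereas compound 3 keeps the chain of compound 2 and adds a phenyl to it. Going by the values given here, no measured pair tests a second phenyl on that carbon. Given the small size of a 1.9-fold lower number from compound 1 to compound 2 (0.28 log units; within the scatter), the expected step in this assay is a 1.3-fold lower number from compound 2 to compound 3 (0.10 log units; within the scatter), not beyond the scatter. Compound 3 is therefore estimated at 150 nM, with a range from 50 nM to 450 nM.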

Compound 3, half-maximal inhibitory concentration: 140 nM
For compound 3 the middle estimate is 1.1-fold (0.03 log units) above the measured one, and the stated range covers the measured number.
By their numbers in this assay, from the lowest: compounds 3, 2 and 1 (each within the scatter of the next, the first and the last beyond it).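

Compound 3 gives the first measured test of this saturated chain carbon, bound to an aromatic carbon and a saturated chain carbon, as the earlier pair had altered only the chain length. In this assay the exchange of hydrogen for phenyl gives a 1.4-fold lower number from compound 2 to compound 3 (0.13 log units; within the scatter) and so adds 6 heavy atoms and one six-membered aromatic ring of carbon only at this place with no difference from compound 2 beyond the scatter; this place therefore tolerates a second phenyl, but the data show no gain from it. No measurement shown accounts for this tolerance.

The compounds shown leave open whether a smaller group on this carbon, such as methyl or hydroxyl, or a charged one, such as a dimethylamino group or a carboxylic acid, would also stay within the scatter of compound 2. They also leave open whether a chlorine on either phenyl, or a longer chain carrying both phenyls, would move the number beyond the scatter.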